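Fluoro for methyl on a pyrrolidine-diol scaffold, mirror series

The source may report more compounds than this note shows. Statements on the series, on what has been measured and on what is new or still open speak of the compounds shown alone.

Compound 1, `O[C@H]1[C@H](O)CN[C@@H]1c1ccc(F)cc1`, in an assay on isolated protein for inhibition of alpha-mannosidase (Canavalia ensiformis), read by spectrophotometry, tested at 1000 uM (a lower number here means less inhibition, a higher number more inhibition at the concentration tested (going by the name of the read-out)), gives 0.8%.
Compound 2, `Cc1ccc([C@H]2NC[C@@H](O)[C@@H]2O)cc1`, gives 0%.
Compound 3, `Cc1ccc([C@@H]2NC[C@H](O)[C@H]2O)cc1`, gives 0.4%.

Compound 3 sits second highest of the three numbers, but its gaps to compound 1 and to compound 2 both lie within the scatter, so the three compounds cannot be told apart in this assay. Compound 4, `O[C@@H]1[C@@H](O)CN[C@H]1c1ccc(F)cc1`, has not yet been measured; it differs from compound 3 by fluoro in place of methyl on an aromatic carbon.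

Among the compounds with values here, two measured steps bear on this change. The first, a number 0.8 percentage points lower from compound 1 to compound 2 (within the scatter), is the same exchange taken in the other direction, and it produced no movement beyond the scatter. The second, a number 0.4 percentage points higher from compound 2 to compound 3 (within the scatter), shows that inverting all stereocentres likewise left the number unchanged, a point that rests on (the fact that compounds 2 and 3 differ only in the configuration as drawn). Neither step gives a reason to expect that swapping fluoro back in for methyl on the core of compound 3 will shift the read-out.

Compound 4 is therefore expected to show a step of a number 0.1 percentage points higher from compound 3 to compound 4 (within the scatter), that is, no change beyond the scatter. The estimate for compound 4 is 0.5%, in a range from 0% to 6%.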

Compound 4, a percentage reported as inhibition, at one concentration (the size of the read-out at that concentration, not a potency): 1.2%
Beside the measured number, compound 4's estimate is 0.7 percentage points below it; low and high end bracket the measured number.
By their numbers in this assay, from the lowest: compounds 2, 3, 1 and 4 (each within the scatter of the next).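

In this assay, the exchange of methyl and fluoro on the aromatic carbon, para to a group of 7 heavy atoms, now has a reading on the mirror-image core as well, with a number 0.8 percentage points higher from compound 3 to compound 4 (within the scatter), and the exchange behaves alike on both cores: the same change on two cores in this assay, a number 0.8 percentage points lower (within the scatter) from compound 1 to compound 2 and a number 0.8 percentage points lower (within the scatter) from compound 4 to compound 3, 0 percentage points apart, within the scatter of two such steps

Inverting all stereocentres had earlier been read only for the methyl pair; it now has a reading for the fluoro pair too, with a number 0.4 percentage points higher from compound 1 to compound 4 (within the scatter), and this step also stays within the scatter: the fact that compounds 1 and 4 differ only in the configuration as drawn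

So on these compounds neither the group at this position nor the configuration as drawn produces a step beyond the scatter, and every step read here stays close to nothing at the one concentration tested.

The compounds shown leave open whether a carboxylic acid, an amine or a longer chain at this aromatic carbon would give a step beyond the scatter. They also leave open whether methyl and fluoro would differ at all on a core that gives clearly more inhibition in this assay.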